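A few compounds are considered here, and "the series" means these few. Any claim that something is new, unique, unknown or untested is made for them only; others in the source may bear on it.

Measured so far:
compound 1 `CNC(=O)N1CCCc2ccc(NC(=O)c3ccc(-c4cc[nH]n4)cc3)cc21`: 92.5%
compound 2 `CNC(=O)N1CCCc2ccc(NC(=O)c3cccc(-c4ccccc4)c3)cc21`: 2.83%
compound 3 `CNC(=O)N1CCCc2ccc(NC(=O)c3ccc(-c4ccn(C)n4)cc3)cc21`: 72.2%

In a functional assay on MV4-11 cells (Homo sapiens) for antiproliferative activity, with a stated time of 6 days, tested at 1.56 uM (on this read-out higher numbers stand for a stronger effect at the one concentration tested and lower numbers for a weaker effect), compound 3 stands second highest of the three numbers: compound 1 sits above it by a number 20.3 percentage points lower from compound 1 to compound 3 (beyond the scatter), while compound 2 sits far below it. Compound 4 `CNC(=O)N1CCCc2ccc(NC(=O)c3ccc(-c4ccncc4)cc3)cc21` arises from compound 3 by pyridin-4-yl in place of 1-methyl-1H-pyrazol-3-yl on an aromatic carbon. Among the measured compounds shown here, no measured step covers a swap of one aromatic ring for another; the only single-place step, from compound 1 to compound 3, changed only a methyl on an aromatic nitrogen and was modest, and compound 2 differs from compound 3 in two places at once. The estimate therefore leans on compound 3 giving 72.2%, with wide uncertainty, and the expected step is a number 22.2 percentage points lower from compound 3 to compound 4 (beyond the scatter). Compound 4 is estimated at 50%, between 15% and 85%.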

Compound 4, a percentage reported as inhibition, at one concentration (the size of the read-out at that concentration, not a potency): 37.6%
The estimate for compound 4 lay 12.4 percentage points above the measured number, and the stated range covers the measured number.
By their numbers in this assay, from the lowest: compound 2; then compound 4; then compound 3; then compound 1.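

Replacing the whole ring on this aromatic carbon, para to a large group, counts as a large change, whereas adding the methyl on nitrogen was modest. In this assay pyridin-4-yl gives a number 34.6 percentage points lower from compound 3 to compound 4 (beyond the scatter) and, against the 1H-pyrazol-3-yl ring, a number 54.9 percentage points lower from compound 1 to compound 4 (beyond the scatter) so this six-membered ring keeps only part of the effect seen with either five-membered ring. No measured evidence accounts for these drops. Going by these compounds, how an open-chain amine or a carboxylic acid would behave on this same carbon remains open.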